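Working notes: fluoro to chloro on compound 1

The source may hold more compounds than are shown below. What is called first, only, known or untested is meant among the compounds shown, and "the series" means these compounds.

Measured in a functional assay on microsomes for inhibition, with a stated time of 1 h; on this read-out lower numbers stand for stronger inhibition and higher numbers for weaker inhibition:
- compound 1 `CCOC(=O)c1cnn(-c2nc(-c3ccccc3F)c(C#N)c(=O)n2C)c1N` gives 94 ug/mL
- compound 2 `CSc1nc(-c2cccs2)c(C#N)c(=O)n1C` gives 83 ug/mL
- compound 3 `Cn1c(NN)nc(-c2ccccc2O)c(C#N)c1=O` gives 34 ug/mL

Compound 1 and compound 2 lie within the scatter of each other, while compound 3 gives a lower number than compound 1, beyond the scatter. Compound 4 `CCOC(=O)c1cnn(-c2nc(-c3ccccc3Cl)c(C#N)c(=O)n2C)c1N` has chloro in place of fluoro on an aromatic carbon, ortho to a large group (chloro in place of fluoro on an aromatic carbon). Among the compounds with values here, no measured pair differs in one place alone, and the data offer no direct guide to this change. No step beyond the scatter is expected in this assay. The estimated step of a 1.1-fold lower number from compound 1 to compound 4 (0.04 log units; within the scatter) is expected to stay within the scatter. For compound 4 the estimated value is 85 ug/mL, with an expected range of 45 ug/mL to 160 ug/mL.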

Compound 4, half-maximal inhibitory concentration: 102 ug/mL
Beside the measured number, compound 4's estimate is 1.2-fold (0.08 log units) below it; the range from low to high includes it.
By their numbers in this assay, from the lowest: compound 3; then compounds 2, 1 and 4 (each within the scatter of the next).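

In this assay, 2-fluorophenyl to 2-chlorophenyl gives a 1.1-fold higher number from compound 1 to compound 4 (0.04 log units; within the scatter). Within the data shown here, this is the first step that differs in one place alone, and it shows that chloro can stand in place of fluoro on this aromatic carbon without a step beyond the scatter. No measured evidence bears on this result.

The compounds shown leave open whether an amine or a methoxy group on the same aromatic carbon would give a step beyond the scatter. Also open, going by these compounds, is the effect of a carboxylic acid in place of the ethyl ester.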